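Cytotoxicity notes: from compound 3 to compound 4

The compounds below may be only part of what the source reports. "The series", "measured", "known", "first", "only" and "open" are said of these compounds alone.

Going by the values given here, in an ADME assay on cells (Homo sapiens) for cytotoxicity, read by resazurin assay, with a stated time of 5 days (on this read-out lower numbers stand for higher toxicity in this test and higher numbers for lower toxicity in this test), compound 3 `O=S(=O)(Cc1nc(-c2ccnc(Cl)c2)c2sccc2n1)c1cccc(Cl)c1` gives 63000 nM, the only number among the three values so far. Compound 1 `O=S(=O)(Cc1nc(-c2ccncc2)c2sccc2n1)c1cccc(Cl)c1` reads > 50000 nM, which is a limit of the assay and not a number. Compound 2 `COc1ccc(-c2nc(CS(=O)(=O)c3cccc(Cl)c3)nc3ccsc23)cn1` reads > 10000 nM, which is also a limit.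

Compound 4 `COc1ccc(-c2nc(CS(=O)(=O)c3cccc(Cl)c3)nc3ccsc23)cc1` differs from compound 3 in one place, with 4-methoxyphenyl in place of 2-chloropyridin-4-yl on an aromatic carbon.

The measured steps that bear on this change are a step that the two limits leave unreadable from compound 1 to compound 2, a step that the limit leaves unreadable from compound 1 to compound 3 and a step that the limit leaves unreadable from compound 2 to compound 3, all within the group at this same place. None of them offers a size to carry over, so no step beyond the scatter is expected in this assay, in either direction. The anchor is therefore compound 3 at 63000 nM. The expected change is a 1.3-fold lower number from compound 3 to compound 4 (0.10 log units; within the scatter). For compound 4 the estimated value is 50000 nM, with an expected range of 15000 nM to 130000 nM.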

Compound 4, half-maximal cytotoxic concentration: 69000 nM
Estimate against measurement, compound 4: 1.4-fold (0.14 log units) below, within the range that was stated.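

In this assay, going by these compounds alone, the change from 2-chloropyridin-4-yl to 4-methoxyphenyl gives the first step of readable size at this place, a 1.1-fold higher number from compound 3 to compound 4 (0.04 log units; within the scatter). For this pair, a ring of carbon only in place of a ring with one hetero atom, with methoxy in place of chloro, brings no change beyond the scatter. The steps from compound 1 and from compound 2 to compound 4 cannot be read, as each of those two compounds stands at a limit of the assay and not at a number.

As far as these compounds go, how compound 1 and compound 2 truly compare with compound 3 and compound 4 stays open. Also open, from the compounds shown here alone, is whether an amine or a carboxylic acid on this aromatic ring would move the number in this assay beyond the scatter.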